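The source may report more compounds than this note shows. Statements on the series, on what has been measured and on what is new or still open speak of the compounds shown alone.

Measured so far in an ADME assay on 184B5 cells (Homo sapiens) for cytotoxicity, read by MTT assay, with a stated time of 72 h; a lower number here means a stronger inhibitor of growth, a higher number a weaker inhibitor of growth:
compound 1, `CC(C)COC(=O)Nc1ccc([Se][Se]c2ccc(NC(=O)OCC(C)C)cc2)cc1`: 5500 nM
compound 2, `CCCOC(=O)Nc1ccc([Se]C#N)cc1`: 3700 nM
compound 3, `CCCCOC(=O)Nc1ccc([Se][Se]c2ccc(NC(=O)OCCCC)cc2)cc1`: 7200 nM

The three numbers sit close together. The gap between compound 2 and compound 1 and the gap between compound 2 and compound 3 both lie within the usual scatter of this assay, so compound 2 cannot be set apart from either of the others on these figures; the three compounds read as one group.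

Compound 4 `N#C[Se]c1ccc(NC(=O)OCc2ccccc2)cc1` has not yet been measured. It differs from compound 2 in one place: phenyl in place of ethyl on a saturated chain carbon bound to an oxygen next to a carbonyl group. Going by the values given here, no measured pair isolates this change, and compounds 1 and 3 differ from compound 2 elsewhere in the molecule as well, so the record offers no direct guide to its effect. Given that all three measured compounds fall within the scatter of one another despite their differences, the author expects the step of a 1.1-fold lower number from compound 2 to compound 4 (0.02 log units; within the scatter) to be small, in no set direction, and not beyond the scatter. Compound 4 is accordingly estimated at 3500 nM, with a range from 1500 nM to 8500 nM.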

Compound 4, concentration for 50% growth inhibition: 5000 nM
Estimate against measurement, compound 4: 1.4-fold (0.15 log units) below; the measured number falls inside the stated range.
By their numbers in this assay, from the lowest: compounds 2, 4, 1 and 3 (each within the scatter of the next).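

In this assay, going by these compounds alone, compounds 2 and 4 form the first pair that differs in one place, and putting phenyl in place of ethyl on a saturated chain carbon bound to an oxygen next to a carbonyl group gives a 1.4-fold higher number from compound 2 to compound 4 (0.13 log units; within the scatter). Within the data shown here, this position therefore accepts a six-membered aromatic ring of carbon only with no step that can be told from the scatter, although this single pair cannot show how far that holds. No evidence is available that bears on this result.

Still open, from the compounds shown here alone, is whether an amine, a carboxylic acid or a longer chain at this place would give a step beyond the scatter. Also open, going by these compounds, is whether a phenyl carrying a fluorine or a methoxy group would read as the plain phenyl does.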